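This account rests on a few compounds, and the source may have more. Where it says the series, first, only, none or still open, it means among the compounds named here.

Measured compounds:
compound 1 `CC(C)c1ccc(COc2ccccc2C2CC(=O)c3ccccc3O2)cc1` — 91.5%
compound 2 `O=C1CC(c2ccccc2OCc2ccc(F)cc2)Oc2ccccc21` — 45.2%
compound 3 `COc1ccccc1C1CC(=O)c2ccccc2O1` — 37.3%

In a functional assay on RAW264.7 cells (Mus musculus) for inhibition, read by immunoassay, with a stated time of 12 h, tested at 30 uM (on this read-out higher numbers stand for more inhibition at the one concentration tested (going by the name of the read-out) and lower numbers for less inhibition), compound 3 gives 37.3%, the lowest of the three numbers; compound 2 sits a number 7.9 percentage points lower from compound 2 to compound 3 (within the scatter) away, compound 1 a number 54.2 percentage points lower from compound 1 to compound 3 (beyond the scatter). Compound 4 `CC(C)CCOc1ccccc1C1CC(=O)c2ccccc2O1` differs from compound 3 by isobutyl in place of hydrogen on a saturated chain carbon bound to an oxygen on an aromatic ring. Going by the values given here, two measured steps touch the same place: a number 54.2 percentage points lower from compound 1 to compound 3 (beyond the scatter), and a number 7.9 percentage points lower from compound 2 to compound 3 (within the scatter). Among the compounds with values here, both replace a hydrogen there with a larger group, one with a large gain and one without change beyond the scatter, so the step to compound 4 is expected to run upward, but the data give no step with a chain there, and the size is uncertain. Compound 4 is expected to give 55%, between 30% and 80%, a step of a number 17.7 percentage points higher from compound 3 to compound 4 (beyond the scatter).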

Compound 4, a percentage reported as inhibition, at one concentration (the size of the read-out at that concentration, not a potency): 47.6%
Estimate against measurement, compound 4: 7.4 percentage points above; the measured number falls inside the stated range.
By their numbers in this assay, from the lowest: compounds 3, 2 and 4 (each within the scatter of the next, the first and the last beyond it); then compound 1.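

In this assay a chain without a ring at this position also moves the number, with a number 10.3 percentage points higher from compound 3 to compound 4 (beyond the scatter) for isobutyl in place of hydrogen. Set against 4-fluorophenyl the chain shows no real difference, with a number 2.4 percentage points higher from compound 2 to compound 4 (within the scatter) for that exchange, whereas 4-isopropylphenyl keeps a clear lead, with a number 43.9 percentage points lower from compound 1 to compound 4 (beyond the scatter) on going to the chain. A larger group here therefore does not by itself reach the level of compound 1. From the compounds shown here alone, whether a longer chain or an amine in place of isobutyl would close that gap stays open. No measurement at hand says why these groups differ.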